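Trifluorobenzyl to pyridylmethyl on the shared core

This account rests on a few compounds, and the source may have more. Where it says the series, first, only, none or still open, it means among the compounds named here.

For the measured compounds named here, compound 2 `COc1ccc2[nH]c3c(c2c1)CCNC31CCN(Cc2cc(F)c(F)cc2F)CC1` gives 600 nM in an assay on FRT cells for positive allosteric modulation of Cystic fibrosis transmembrane conductance regulator variant N1303K (Homo sapiens), in the presence of a further agent that is not named here (a higher number here means that more compound is needed for the effect, a lower number that less compound is needed), the lowest of the two numbers measured so far; its nearest neighbour, compound 1 `COc1ccc2[nH]c3c(c2c1)CCNC31CCN(Cc2cc(F)cc(F)c2)CC1`, gives 11100 nM. Going by the values given here, the one measured step, a 19-fold lower number from compound 1 to compound 2 (1.27 log units; beyond the scatter), shows that the aryl group on the saturated chain carbon bound to the amine nitrogen in the ring can move the number strongly even when only the fluorine pattern changes. Compound 3 `COc1ccc2[nH]c3c(c2c1)CCNC31CCN(Cc2ccccn2)CC1` carries pyridin-2-yl in place of 2,4,5-trifluorophenyl on a saturated chain carbon bound to an amine nitrogen in a ring. Among the compounds with values here, no measured step covers the loss of the fluorines or the entry of a ring nitrogen, so that step speaks only to how sensitive this position is. The fluorine pattern that the measured step rewarded is gone in compound 3, and a rise in this assay beyond the scatter is expected, of about an 8.3-fold higher number from compound 2 to compound 3 (0.92 log units; beyond the scatter). Compound 3 is accordingly estimated at 5000 nM, within a range from 1000 nM to 30000 nM.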

Compound 3, half-maximal effective concentration: 11500 nM
The estimate for compound 3 lay 2.3-fold (0.36 log units) below the measured number; low and high end bracket the measured number.
By their numbers in this assay, from the lowest: compound 2; then compounds 1 and 3 (each within the scatter of the next).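

In this assay the change to pyridin-2-yl on a saturated chain carbon bound to an amine nitrogen in a ring gives a 19-fold higher number from compound 2 to compound 3 (1.28 log units; beyond the scatter) and so removes the whole advantage held by the 2,4,5-trifluorophenyl group. The same group set against 3,5-difluorophenyl gives a 1.0-fold higher number from compound 1 to compound 3 (0.02 log units; within the scatter) and thus does not separate a ring of carbon only bearing fluorines from a ring with a nitrogen and no fluorine. Among these three compounds, then, only the 2,4,5-trifluorophenyl group stands apart, and nothing available explains this result.

The compounds shown leave open how plain phenyl, with no fluorine at all, would compare with these groups. They also leave open whether a pyridine ring carrying fluorine would recover the number of compound 2.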